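Thiourea Analogue Replacing a Methoxyphenyl With Pyridinyl

The source may report more compounds than this note shows. Statements on the series, on what has been measured and on what is new or still open speak of the compounds shown alone.

Measured compounds:
compound 1 `N#Cc1ccccc1CN1CCc2c(sc(NC(=O)c3ccccc3Cl)c2C(N)=O)C1` — 9500 nM
compound 2 `NC(=O)c1c(NC(=O)c2ccccc2Cl)sc2c1CCN(Cc1ccccc1Cl)C2` — 4430 nM
compound 3 `COc1ccccc1NC(=S)N1CCc2c(sc(NC(=O)c3ccccc3Cl)c2C(N)=O)C1` — 35200 nM

In a functional assay on MKN-74 cells (Homo sapiens) for antiproliferative activity, with a stated time of 24 h (on this read-out lower numbers stand for stronger inhibition and higher numbers for weaker inhibition), compound 3 gives the highest number of the three. Its nearest neighbour is compound 1, reached by a 3.7-fold higher number from compound 1 to compound 3 (0.57 log units; beyond the scatter), and the widest gap is to compound 2, reached by a 7.9-fold higher number from compound 2 to compound 3 (0.90 log units; beyond the scatter). Both of those steps exchange the whole group on the ring amine nitrogen, and both point the same way: the thiourea-bearing compound 3 sits above the two benzyl-type compounds. The remaining step, a 2.1-fold lower number from compound 1 to compound 2 (0.33 log units; beyond the scatter), concerns only the benzyl ring of those two and says nothing about the thiourea.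

Compound 4 `NC(=O)c1c(NC(=O)c2ccccc2Cl)sc2c1CCN(C(=S)Nc1cccnc1)C2` keeps the thiourea of compound 3 and changes only the ring on its outer nitrogen: pyridin-3-yl in place of 2-methoxyphenyl on an amide-type nitrogen. Within the data shown here, no measured pair shows what such an exchange does on this nitrogen, so the account must rest on compound 3 alone, which gives 35200 nM in this assay. Among the measured compounds shown here, with no step of this kind available, the expectation is that compound 4 stays near compound 3, with a step of a 1.2-fold lower number from compound 3 to compound 4 (0.07 log units; within the scatter) that is not expected to pass beyond the scatter. Compound 4 is therefore estimated at 30000 nM, within a range from 10000 nM to 90000 nM.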

Compound 4, half-maximal inhibitory concentration: 38600 nM
Estimate against measurement, compound 4: 1.3-fold (0.11 log units) below, within the range that was stated.
By their numbers in this assay, from the lowest: compound 2; then compound 1; then compounds 3 and 4 (each within the scatter of the next).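

In this assay, replacing 2-methoxyphenyl with pyridin-3-yl on the amide-type nitrogen gives a 1.1-fold higher number from compound 3 to compound 4 (0.04 log units; within the scatter), so this first measured exchange at that place leaves the read-out within the scatter. The benzyl-type compounds also stand apart from this second thiourea, with an 8.7-fold higher number from compound 2 to compound 4 (0.94 log units; beyond the scatter) and a 4.1-fold higher number from compound 1 to compound 4 (0.61 log units; beyond the scatter), so the gap first seen with compound 3 holds for both thioureas shown, whichever of these two rings sits on the outer nitrogen. No measurement shown offers an explanation for either result.

From the compounds shown here alone, two rings on one nitrogen cannot show whether this insensitivity extends to other groups, so it remains open whether an ethyl chain, or a phenyl ring carrying a carboxylic acid or an amine, would leave the read-out in the same range. Going by these compounds, it is also open whether a urea, with oxygen in place of the thiourea sulfur, would keep the same distance from the benzyl-type compounds, or whether that distance belongs to the thiourea link itself.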